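Benzyloxy Substituent Swap Toward a Nitro Analogue

A few compounds are considered here, and "the series" means these few. Any claim that something is new, unique, unknown or untested is made for them only; others in the source may bear on it.

Compound 1 `COc1cccc(OC)c1OCCNCCOc1ccccc1OCc1cccc(Cl)c1`: 0.0501 nM
Compound 2 `COc1cccc(OC)c1OCCNCCOc1ccccc1OCc1ccc(Cl)cc1`: 0.0316 nM
Compound 3 `COc1cccc(OC)c1OCCNCCOc1ccccc1OCc1cccc(C)c1`: 0.2 nM

In an assay on CHO cells for displacement of a labelled ligand from Alpha-1D adrenergic receptor (Homo sapiens) (on this read-out higher numbers stand for weaker inhibition and lower numbers for stronger inhibition), compound 1 gives 0.0501 nM, the second highest of the three numbers. Its nearest neighbour is compound 2, and the step of a 1.6-fold lower number from compound 1 to compound 2 (0.20 log units; within the scatter) lies within the scatter. The furthest is compound 3, reached by the step of a 4.0-fold higher number from compound 1 to compound 3 (0.60 log units; beyond the scatter). Between the other two, the step of a 6.3-fold higher number from compound 2 to compound 3 (0.80 log units; beyond the scatter) is also beyond the scatter.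

The new compound 4 `COc1cccc(OC)c1OCCNCCOc1ccccc1OCc1ccc([N+](=O)[O-])cc1` differs from compound 1 by 4-nitrophenyl in place of 3-chlorophenyl on a saturated chain carbon bound to an oxygen on an aromatic ring. The change has two parts. Moving the substituent from the 3-position to the 4-position of the phenyl ring is covered by the step from compound 1 to compound 2, which did not exceed the scatter. Replacing chloro by another group is covered only by the step to compound 3, where methyl in place of chloro gave a modest rise. Among the measured compounds shown here, no measured step involves a nitro group, so its effect is not known from these data.

Compound 4 is therefore expected to sit close to compound 1, with a step of a 1.6-fold higher number from compound 1 to compound 4 (0.20 log units; within the scatter) that may not exceed the scatter. The estimate for compound 4 is 0.08 nM, with a range from 0.02 nM to 0.4 nM.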

Compound 4, inhibition constant: 0.0501 nM
Beside the measured number, compound 4's estimate is 1.6-fold (0.20 log units) above it; the measured number falls inside the stated range.
By their numbers in this assay, from the lowest: compounds 2, 1 and 4 (each within the scatter of the next); then compound 3.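

In this assay, the first nitro-bearing group seen at this position leaves the number in the range set by the two chlorinated compounds: 4-nitrophenyl in place of 3-chlorophenyl on a saturated chain carbon bound to an oxygen on an aromatic ring gives no change at the digits printed from compound 1 to compound 4 (within the scatter), and a plain exchange of chloro for nitro gives a 1.6-fold higher number from compound 2 to compound 4 (0.20 log units; within the scatter). Replacing chloro therefore need not carry the penalty seen with methyl, since the nitro swap stays within the scatter on both comparisons, while 4-nitrophenyl in place of 3-methylphenyl gives a 4.0-fold lower number from compound 3 to compound 4 (0.60 log units; beyond the scatter) and leaves compound 3 as the only one of the four set apart from the rest. Nothing in the available evidence accounts for this result, so the data describe the pattern without explaining it.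

Methyl appears here only as 3-methylphenyl and nitro only as 4-nitrophenyl, so it remains open whether 4-methylphenyl would join the other three compounds or 3-nitrophenyl would stay with them. Also open, going by these compounds, is how an unsubstituted phenyl, or a phenyl ring carrying an amine or a carboxylic acid, would read at this place.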